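Working notes: fluoro for methyl in a cytotoxicity series

The source may report more compounds than this note shows. Statements on the series, on what has been measured and on what is new or still open speak of the compounds shown alone.

Of the compounds shown here, three on a shared core have been measured in an ADME assay on RAW264.7 cells (Mus musculus) for cytotoxicity, read by MTT assay, with a stated time of 48 h; on this read-out lower numbers stand for stronger inhibition and higher numbers for weaker inhibition. Compound 1 `Cc1cc(NC(=O)c2ccc(Cl)c([N+](=O)[O-])c2)ccc1NS(C)(=O)=O` gives 108000 nM. Compound 2 `CCS(=O)(=O)Nc1ccc(NC(=O)c2ccc(Cl)c([N+](=O)[O-])c2)cc1C` gives 141000 nM in this assay, and compound 3 `Cc1cc(NC(=O)c2ccc(Cl)c([N+](=O)[O-])c2)ccc1NS(=O)(=O)C(F)(F)F` gives 89800 nM. Compound 1 stands second highest of the three numbers, with compound 3 nearest and compound 2 furthest; the steps of a 1.3-fold higher number from compound 1 to compound 2 (0.12 log units; within the scatter), a 1.2-fold lower number from compound 1 to compound 3 (0.08 log units; within the scatter) and a 1.6-fold lower number from compound 2 to compound 3 (0.20 log units; within the scatter) all lie within the scatter, so the three values are read as one level.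

Compound 4 `CS(=O)(=O)Nc1ccc(NC(=O)c2ccc(Cl)c([N+](=O)[O-])c2)cc1F` is not yet measured. It differs from compound 1 by fluoro in place of methyl on an aromatic carbon. Going by the values given here, no measured step touches this change: the three measured steps all vary the group on the sulfonyl sulfur, and none of them alters the methyl that leaves here. With nothing in the measured steps pointing away from the common level, the expected step is no change at the digits printed from compound 1 to compound 4 (within the scatter), none beyond the scatter. Compound 4 is therefore estimated at 108000 nM in this assay, in the range 54000 nM to 216000 nM.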

Compound 4, half-maximal inhibitory concentration: 102000 nM
The estimate for compound 4 lay 1.1-fold (0.02 log units) above the measured number; measured number inside the range.
By their numbers in this assay, from the lowest: compounds 3, 4, 1 and 2 (each within the scatter of the next).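

The aromatic carbon ortho to the methanesulfonamido group now has a step of its own: in this assay, fluoro in place of methyl gives a 1.1-fold lower number from compound 1 to compound 4 (0.02 log units; within the scatter) and leaves the number at the level already seen. The earlier compounds shown here varied only the group on the sulfonyl sulfur, so the level now also holds across one change on the aromatic ring. No measured evidence bears on why this exchange leaves the number in place.

Other groups on this aromatic carbon, such as methoxy, chloro or an amine, remain open, so the reading rests on methyl and fluoro alone. Also open, going by these compounds, is how the number responds when the nitro group of the shared core gives way to an amine or a nitrile.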